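Swapping Nitro for Amino at the Assay Limit

The source may report more compounds than this note shows. Statements on the series, on what has been measured and on what is new or still open speak of the compounds shown alone.

Measured in a functional assay on Malme-3M cells (Homo sapiens) for cytotoxicity, read by MTT assay, with a stated time of 6 days; on this read-out higher numbers stand for an effect only at larger amounts of compound and lower numbers for an effect already at smaller amounts:
compound 1 `COc1ccc2oc(-c3ccc(O)cc3)c(C(=O)O)c(=O)c2c1`: > 25 ug/mL
compound 2 `O=c1cc(-c2ccc([N+](=O)[O-])cc2)oc2ccc(O)cc12`: > 25 ug/mL

Neither entry is a true number. Compound 1 gives > 25 ug/mL, which is a limit of the assay. Compound 2 gives > 25 ug/mL, which is also a limit. For the measured compounds named here, compound 2 therefore stands with the only other measured compound, as this summary shows: the limit of > 25 ug/mL in this assay, at which 2 of the 2 values shown sit. Going by the values given here, its actual position beyond that limit is unknown, and no measured pair of compounds differing in one place is available for comparison.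

Compound 3 `Nc1ccc(-c2cc(=O)c3cc(O)ccc3o2)cc1` differs from compound 2 in one place: amino in place of nitro on an aromatic carbon, para to a large group (amino in place of nitro on an aromatic carbon). Among the compounds with values here, with no measured step to serve as a guide, any forecast is uncertain. In this assay, a small shift toward an effect at smaller amounts is expected, though it may stay within the usual scatter, and another limit is quite possible. The expected change is an at least 1.1-fold lower number from compound 2 to compound 3 (0.05 log units; that floor lies within the scatter). For compound 3, the estimated value is 22 ug/mL. The expected range runs from 8 ug/mL to 50 ug/mL.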

Compound 3, concentration for half-maximal effect: > 25 ug/mL
Compound 3 ended at the assay's limit; the forecaster's own chance of this, stated with the estimate: 55%; middle value at least 1.1-fold (0.05 log units) away from the limit.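

In this assay compound 3 gives > 25 ug/mL, which is a limit of the assay and not a number. Compound 2 also sits at a limit, so no step can be read for amino in place of nitro between compound 2 and compound 3. All the compounds shown share one position: the limit of > 25 ug/mL in this assay, at which 3 of the 3 values shown sit.

The compounds shown leave open how far each lies beyond that limit, and whether this swap changes the effect at all.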